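Alkyl thiourea series: isopropyl in place of methyl

A few compounds are considered here, and "the series" means these few. Any claim that something is new, unique, unknown or untested is made for them only; others in the source may bear on it.

Compound 1 `O=c1ccc(-c2ccccc2)nn1CCCCNC(=S)Nc1ccccc1` and compound 2 `CC/N=C(\S)NCCCCn1nc(-c2ccccc2)ccc1=O` share one core and differ at the amine nitrogen of the thiourea. In a functional assay on the whole organism (stomach) with Rattus norvegicus as the target (a lower number here means that less compound is needed, a higher number that more compound is needed for the effect), compound 1 reaches only a limit of the assay, > 100 mg/kg. In this assay, among the measured compounds shown here, compound 2 gives 37.2 mg/kg, the only numeric value in the set. The step of an at least 2.6-fold lower number from compound 1 to compound 2 (0.42 log units; beyond the scatter) therefore rests on a limit of > 100 mg/kg in this assay, at which 1 of the 2 values shown sits, at one end and is known only as a lower bound on its size.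

Compound 3 `CC(C)C/N=C(\S)NCCCCn1nc(-c2ccccc2)ccc1=O` differs from compound 2 by isopropyl in place of methyl on a saturated chain carbon bound to a double-bonded nitrogen. For the measured compounds named here, this change sits one bond beyond the double-bonded nitrogen, inside the alkyl group that was itself the entering piece in the step from compound 1 to compound 2; no measured step reports a change of this kind, and the one measured step concerns a ring against a chain, not a branch within a chain. With nothing pointing either way, the expectation for this assay is no step beyond the scatter, a 1.0-fold lower number from compound 2 to compound 3 (0.00 log units; within the scatter), so compound 3 is estimated at 37 mg/kg, with a range from 14 mg/kg to 95 mg/kg.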

Compound 3, dose for half-maximal effect: > 100 mg/kg
Compound 3: a limit, no number (the forecaster's own chance of this, stated with the estimate: 15%); at least 2.7-fold (0.43 log units) between middle value and limit.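

Compound 3 reaches only a limit in this assay, > 100 mg/kg. Isopropyl in place of methyl on a saturated chain carbon bound to a double-bonded nitrogen gives an at least 2.6-fold higher number from compound 2 to compound 3 (0.42 log units; beyond the scatter), so this position responds to a change within the alkyl group itself, and a ring against a chain is no longer the only change here with a readable step. Compound 1 and compound 3 cannot be ordered against each other, and the step between them cannot be read: the limit of > 100 mg/kg in this assay, at which 2 of the 3 values shown sit.

The step to compound 3 is known only as a lower bound on its size, and with a single numeric value in the set, no trend in the size of the alkyl group can be drawn. On these data alone, what stays open is whether branching or the added carbon count goes with the higher number: a straight propyl or butyl chain at this place would separate the two, and a methyl directly on the double-bonded nitrogen would show whether the series extends to a smaller group.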